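Benzylsulfanyl variation on the sulfonylguanidine series: compound 4

The source may report more compounds than this note shows. Statements on the series, on what has been measured and on what is new or still open speak of the compounds shown alone.

Measured so far in a functional assay on MCF7 cells (Homo sapiens) for cytotoxicity, read by MTT assay, with a stated time of 72 h; a lower number here means a stronger inhibitor, a higher number a weaker inhibitor:
compound 1 `Cc1cccc(CSc2cc(Cl)c(C)cc2S(=O)(=O)/N=C(\N)n2nccc2-c2ccccc2)c1` gives 47000 nM
compound 2 `Cc1cc(S(=O)(=O)/N=C(\N)n2nccc2-c2ccccc2)c(SCc2ccccc2C)cc1Cl` gives 23000 nM
compound 3 `Cc1ccc(CSc2cc(Cl)c(C)cc2S(=O)(=O)/N=C(\N)n2nccc2-c2ccccc2)cc1` gives 21000 nM

Among the measured compounds shown here, compound 3 has the lowest of the three numbers, though its gap to compound 2, a 1.1-fold lower number from compound 2 to compound 3 (0.04 log units; within the scatter), lies within the scatter; only the step of a 2.2-fold lower number from compound 1 to compound 3 (0.35 log units; beyond the scatter) is beyond it.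

Compound 4 `Cc1cc(S(=O)(=O)/N=C(\N)n2nccc2-c2ccccc2)c(SCc2ccccc2C(F)(F)F)cc1Cl` differs from compound 3 by 2-(trifluoromethyl)phenyl in place of 4-methylphenyl on a saturated chain carbon bound to a sulfur. For the measured compounds named here, the steps that bear on this are those moving the methyl around the ring: a 2.0-fold lower number from compound 1 to compound 2 (0.31 log units; beyond the scatter), a 2.2-fold lower number from compound 1 to compound 3 (0.35 log units; beyond the scatter) and a 1.1-fold lower number from compound 2 to compound 3 (0.04 log units; within the scatter). On these data alone, none of them involves a trifluoromethyl, so the change is untested here. From the modest size of these steps, compound 4 is expected to sit near compound 3, with no step beyond the scatter, a 1.2-fold higher number from compound 3 to compound 4 (0.08 log units; within the scatter). Compound 4 is thus estimated at 25000 nM, range 10000 nM to 60000 nM.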

Compound 4, half-maximal inhibitory concentration: 21000 nM
Estimate against measurement, compound 4: 1.2-fold (0.08 log units) above, within the range that was stated.
By their numbers in this assay, from the lowest: compounds 3, 4 and 2 (each within the scatter of the next); then compound 1.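

Among the compounds shown here, in the search for what this position accepts, 2-(trifluoromethyl)phenyl is the only group so far that is not a methyl-bearing phenyl, and in this assay trifluoromethyl in place of methyl on an aromatic carbon leaves the number within the scatter (a 1.1-fold lower number from compound 2 to compound 4 (0.04 log units; within the scatter)), as does the full change from 4-methylphenyl (no change at the digits printed from compound 3 to compound 4 (within the scatter)). For the compounds shown here, the sole step beyond the scatter still starts from the 3-methylphenyl compound (a 2.2-fold lower number from compound 1 to compound 4 (0.35 log units; beyond the scatter)). Nothing available explains this flat response.

On these data alone, whether an amine or a carboxylic acid on this phenyl ring would shift the number remains open. So does the effect of a longer chain between the sulfur and the ring.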